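Shortening a hydroxyalkyl chain on a shared aminopyrimidinone-free core

The source may hold more compounds than are shown below. What is called first, only, known or untested is meant among the compounds shown, and "the series" means these compounds.

Going by the values given here, compound 1, `CCCS(=O)(=O)Nc1ccc(F)c(-c2cc3cnc(NCC4CC4)nc3n(C)c2=O)c1F`, is the only member of this small set with a number in an in vivo ADME assay on the whole organism for pharmacokinetics, with Mus musculus as the target, at a dose of 2.5 mg/kg by the intravenous route (a higher number here means faster removal of the compound, a lower number slower removal), where compound 1 gives 3 mL/min/kg. Compound 2, `CCCS(=O)(=O)Nc1ccc(F)c(-c2cc3cnc(NCCCO)nc3n(C)c2=O)c1F`, carries a (3-hydroxypropyl)amino group in place of the (cyclopropylmethyl)amino group of compound 1; in this assay compound 2 gives "not determined" (no result reported), so no single number places compound 2 anywhere. Compound 3, `CCCS(=O)(=O)Nc1ccc(F)c(-c2cc3cnc(NCCO)nc3n(C)c2=O)c1F`, differs from compound 2 by hydroxy in place of hydroxymethyl on a saturated chain carbon, two bonds along the chain from a nitrogen on an aromatic ring. Among the compounds with values here, because compound 2 has no result in this assay, no measured step anchors this change; the only reference is the slow removal seen for compound 1. The change is small, and no shift beyond the usual scatter of this assay is expected in either direction. Compound 3 is therefore estimated to give about 4 mL/min/kg in this assay, within a range from 1.5 mL/min/kg to 12 mL/min/kg.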

Compound 3, clearance: 74 mL/min/kg
Beside the measured number, compound 3's estimate is 19-fold (1.27 log units) below it, outside the stated range (above it).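

In this assay, hydroxymethyl in place of cyclopropyl on a saturated chain carbon bound to a nitrogen on an aromatic ring gives a 25-fold higher number from compound 1 to compound 3 (1.39 log units; beyond the scatter) and so shows that this position on the shared core is not indifferent: a change at this one place moves the number well beyond the scatter. The step from compound 2 to compound 3 cannot be read, as compound 2 has no number, and the effect of shortening the chain remains unmeasured. Nothing available here accounts for the rise.

The compounds shown leave open whether the rise follows the arrival of the hydroxy group or the loss of the cyclopropyl ring, and where the 3-hydroxypropyl chain falls. A methoxy group or an amine at the end of the 2-hydroxyethyl chain, in place of its hydroxy, could help separate these two readings.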